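The source may report more compounds than this note shows. Statements on the series, on what has been measured and on what is new or still open speak of the compounds shown alone.

In a functional assay on KB cells (nasopharynx, Homo sapiens) for antiproliferative activity (a higher number here means a weaker inhibitor, a lower number a stronger inhibitor), three sulfonamides sharing one core have been measured. Compound 1 `COc1ccc(S(=O)(=O)Nc2cccc3cc[nH]c23)cc1` gives 0.67 ug/mL, compound 2 `O=S(=O)(Nc1cccc2cc[nH]c12)c1ccc(Cl)cc1` gives 6 ug/mL, and compound 3 `Nc1ccc(S(=O)(=O)Nc2cccc3cc[nH]c23)cc1` gives 36 ug/mL. Compound 3 therefore has the highest number of the three and is the weakest inhibitor of the set. Among the measured compounds shown here, the series so far varies only one group on the aromatic ring of the sulfonyl side: a 9.0-fold higher number from compound 1 to compound 2 (0.95 log units; beyond the scatter) with chloro in place of methoxy, a 54-fold higher number from compound 1 to compound 3 (1.73 log units; beyond the scatter) with amino in place of methoxy, and a 6.0-fold higher number from compound 2 to compound 3 (0.78 log units; beyond the scatter) with amino in place of chloro.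

Compound 4 `Nc1ccc(S(=O)(=O)Nc2cccc3c(Cl)c[nH]c23)cc1` keeps the amino group of compound 3 and changes the core instead: chloro in place of hydrogen on an aromatic carbon. For the measured compounds named here, no measured step touches that carbon, so the three steps offer only indirect guidance. They do show that a single substitution in this series can move the number well beyond the scatter, by modest to large amounts. Going by the values given here, the direction is less secure, and the only hint is that compound 3 at 36 ug/mL sits at the top of the measured range. A modest shift towards a stronger inhibitor is therefore expected, namely a 4.5-fold lower number from compound 3 to compound 4 (0.65 log units; beyond the scatter). For compound 4 the estimated value is 8 ug/mL, with an expected range from 1.5 ug/mL to 40 ug/mL.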

Compound 4, half-maximal inhibitory concentration: 10 ug/mL
For compound 4 the middle estimate is 1.3-fold (0.10 log units) below the measured one; the measured number falls inside the stated range.
By their numbers in this assay, from the lowest: compound 1; then compounds 2 and 4 (each within the scatter of the next); then compound 3.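

In this assay, placing chloro in place of hydrogen on an aromatic carbon of the five-membered aromatic ring, two ring bonds from the ring nitrogen, gives a 3.6-fold lower number from compound 3 to compound 4 (0.56 log units; beyond the scatter) in a change that leaves the amino group untouched. This is the first step shown on the shared core, and it establishes that this carbon, as well as the group on the aromatic ring of the sulfonyl side, can move the number beyond the scatter, here towards a stronger inhibitor. Its size is of the same modest class as the step of a 6.0-fold higher number from compound 2 to compound 3 (0.78 log units; beyond the scatter) on the sulfonyl side, while the step of a 54-fold higher number from compound 1 to compound 3 (1.73 log units; beyond the scatter) remains the largest one shown, and no available evidence bears on why the new chloro has this effect.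

The compounds shown give this step only with the amino group in place, so it remains open whether the same chloro would shift the number by a similar amount alongside the methoxy group of compound 1 or the chloro group of compound 2. They also leave open how this carbon would respond to other substituents, such as bromo, methyl, nitrile or a carboxylic acid, and whether any of these would go beyond the step seen with chloro.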